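A Methyl in Place of Fluoro on an Aromatic Carbon

This account rests on a few compounds, and the source may have more. Where it says the series, first, only, none or still open, it means among the compounds named here.

Of the compounds shown here, three have been measured in an ADME assay on MDCK cells (Canis lupus familiaris) for cytotoxicity, read by MTT assay, with a stated time of 24 h; a higher number here means that more compound is tolerated, a lower number that less compound is tolerated. Here compound 1 `Cc1cc(CNS(=O)(=O)c2ccc(C#N)cc2)c(C)o1` gives 105000 nM. The result for compound 2 `Cc1cc(CNS(=O)(=O)c2ccc(C#N)cc2)c(C)s1` is a limit of the assay, > 217000 nM. Compound 3 `O=S(=O)(NCc1csc2ccccc12)c1ccc(F)cc1` gives 98600 nM, which lies within the scatter of the number for compound 1, so the two cannot be told apart.

Compound 4 `Cc1ccc(S(=O)(=O)NCc2csc3ccccc23)cc1` differs from compound 3 in one place: methyl in place of fluoro on an aromatic carbon. It carries methyl in place of fluoro on an aromatic carbon, para to a large group. Among the compounds with values here, no measured pair in this small set differs in one place only, so the data offer no direct guide to this change. No step beyond the scatter is therefore expected in this assay, and no direction is favoured. The starting point is compound 3 at 98600 nM. The expected step is a 1.0-fold higher number from compound 3 to compound 4 (0.01 log units; within the scatter). For compound 4, the estimated value is 100000 nM, with an expected range from 45000 nM to 220000 nM.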

Compound 4, half-maximal cytotoxic concentration: > 210000 nM
Compound 4: only a limit was reported; the forecaster's own chance of this, stated with the estimate: 20%; middle value at least 2.1-fold (0.32 log units) away from the limit.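

In this assay, within the data shown here, the change from 4-fluorophenyl to 4-methylphenyl gives the only step that can be read in this set: an at least 2.1-fold higher number from compound 3 to compound 4 (0.32 log units; beyond the scatter). It shows that a single replacement at this place, on an aromatic carbon para to a large group, can move the number beyond the scatter, with more compound tolerated with methyl than with fluoro. The full size of the step cannot be read, because the result for compound 4 is a limit and not a number: the limit of > 210000 nM in this assay, at which 1 of the 4 values shown sits.

The compounds shown leave open whether the same change would give a step of this kind on the core of compound 1. They also leave open whether a chloro group, a methoxy group or an amine in the same place would track with fluoro or with methyl.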